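This account rests on a few compounds, and the source may have more. Where it says the series, first, only, none or still open, it means among the compounds named here.

Measured compounds:
- compound 1, `COc1ccc(Oc2ccc3c(NCCCNCc4cc(F)ccc4OC)ccnc3c2)cc1`, gives 317 10^-6 cm/s in an ADME assay for permeability, using PAMPA, with a stated time of 30 min, at pH 7.4; on this read-out higher numbers stand for higher permeability and lower numbers for lower permeability
- compound 2, `CCC(CC)c1ccc2c(NCCCNCc3cc(F)ccc3OC)ccnc2c1`, gives 23 10^-6 cm/s in this assay

Within the data shown here, compound 2 stands at the lower of the two numbers measured so far in this assay; its only neighbour is compound 1, and the single measured step, a 14-fold lower number from compound 1 to compound 2 (1.14 log units; beyond the scatter), lies well beyond the usual scatter of this kind of measurement.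

Compound 3, `COc1ccc(-c2ccc3c(NCCCNCc4cc(F)ccc4OC)ccnc3c2)cc1`, has not been measured yet. It differs from compound 2 in one place: 4-methoxyphenyl in place of pentan-3-yl on an aromatic carbon. Compound 3 thus carries a 4-methoxyphenyl group where compound 1 carries a 4-methoxyphenoxy group, so the two are close but not the same.

Among the measured compounds shown here, only one measured step bears on this change, a 14-fold lower number from compound 1 to compound 2 (1.14 log units; beyond the scatter), and compound 3 roughly reverses it, swapping the pentan-3-yl group back for a ring that resembles the one in compound 1. A rise of similar size is therefore expected, though the missing bridging oxygen leaves room for compound 3 to fall short of compound 1. The expected step is a 7.0-fold higher number from compound 2 to compound 3 (0.84 log units; beyond the scatter), so for compound 3 the estimate is 160 10^-6 cm/s, within a range from 50 10^-6 cm/s to 400 10^-6 cm/s.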

Compound 3, apparent permeability: 237 10^-6 cm/s
Compound 3: the middle estimate sits 1.5-fold (0.17 log units) below what was measured; the range from low to high includes it.
By their numbers in this assay, from the lowest: compound 2; then compounds 3 and 1 (each within the scatter of the next).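

At this aromatic carbon, pentan-3-yl now sits well below two different groups rather than one, since 4-methoxyphenyl also gives a much higher number in this assay (a 10-fold higher number from compound 2 to compound 3 (1.01 log units; beyond the scatter)). The linking oxygen of 4-methoxyphenoxy makes no difference that this measurement can resolve, as the step from that group to 4-methoxyphenyl stays within the scatter (a 1.3-fold lower number from compound 1 to compound 3 (0.13 log units; within the scatter)). Nothing measured alongside these numbers explains why the two groups carrying a ring stand apart from pentan-3-yl.

Both groups with a ring also carry a methoxy group, so the compounds shown cannot separate the contribution of the ring from that of the methoxy; a plain phenyl group at the same carbon would make that distinction. As far as these compounds go, it also remains open how a shorter chain such as ethyl, or a ring bearing a carboxylic acid or an amine, would compare in this assay, and whether the same ordering would hold with a different group elsewhere on the shared core.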